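The source may report more compounds than this note shows. Statements on the series, on what has been measured and on what is new or still open speak of the compounds shown alone.

Among the measured compounds shown here, in a functional assay on HeLa cells (Homo sapiens) for antiproliferative activity, read by MTT assay, with a stated time of 72 h (on this read-out higher numbers stand for weaker inhibition and lower numbers for stronger inhibition), compound 1 `Nc1nc(N)c2cc(CSC(=S)N3CCN(c4ccc(O)cc4)CC3)ccc2n1` gives 5180 nM, the higher of the only two numbers available, which makes it the weaker inhibitor of the pair. Compound 2 `Cc1ccc(N2CCN(C(=S)SCc3ccc4nc(N)nc(N)c4c3)CC2)cc1` gives 2130 nM. A close relative, compound 3 `Cc1ccccc1N1CCN(C(=S)SCc2ccc3nc(N)nc(N)c3c2)CC1`, offers no number for comparison, as its entry reads "not determined" (no result reported). Still unmeasured in this assay is compound 4 `Nc1nc(N)c2cc(CSC(=S)N3CCN(c4ccc(Cl)cc4)CC3)ccc2n1`, which departs from compound 1 by a single change: chloro in place of hydroxy on an aromatic carbon. Chloro takes the place of hydroxy on an aromatic carbon, para to a large group, so that 4-hydroxyphenyl becomes 4-chlorophenyl. For the measured compounds named here, only one measured step bears on this change, and it also removes the hydroxy, though with methyl entering instead of chloro: a 2.4-fold lower number from compound 1 to compound 2 (0.39 log units; beyond the scatter), modest but beyond the scatter, so a step of similar size toward a lower number is expected here. Going by the values given here, this rests on a single comparison, and no measured step shows chloro itself, so the expectation is loose. The expected step is a 2.4-fold lower number from compound 1 to compound 4 (0.37 log units; beyond the scatter). Compound 4 is estimated at 2200 nM, with an expected range from 800 nM to 5500 nM.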

Compound 4, half-maximal inhibitory concentration: 6990 nM
For compound 4 the middle estimate is 3.2-fold (0.50 log units) below the measured one; measured number above the stated range.
By their numbers in this assay, from the lowest: compound 2; then compounds 1 and 4 (each within the scatter of the next).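

In this assay the swap at this place on the aromatic ring, a 1.3-fold higher number from compound 1 to compound 4 (0.13 log units; within the scatter), lies within the scatter, so the loss of hydroxy does not by itself go with a lower number, and compound 4 goes against any reading of the earlier step as a simple gain from removing it. The comparison of the two groups that replace hydroxy is what separates them, since a 3.3-fold higher number from compound 2 to compound 4 (0.52 log units; beyond the scatter) is a modest step beyond the scatter, and the lower number of the earlier step therefore stays with methyl, not with the departure of hydroxy. Nothing available here accounts for why methyl stands apart from chloro and hydroxy at this place.

Going by these compounds, with a single methyl compound to go on, it remains open whether this lower number is particular to methyl or would also appear with a longer chain such as ethyl, with methoxy, or with an amine at the same place. Steps to compound 3 cannot be read, so whether the placing of methyl on the ring matters also remains open.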